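Replacing 3-fluorophenyl with 4-(dimethylamino)phenyl

A few compounds are considered here, and "the series" means these few. Any claim that something is new, unique, unknown or untested is made for them only; others in the source may bear on it.

compound 1 `NC1CCc2nc(-c3ccncc3)nc(Nc3ccc(F)cc3)c2C1`: 3000 nM
compound 2 `NC1CCc2nc(-c3ccncc3)nc(Nc3cccc(F)c3)c2C1`: 1400 nM
compound 3 `N[C@@H]1CCc2nc(-c3ccncc3)nc(Nc3cccc(F)c3)c2C1`: 1800 nM

These values come from a functional assay on G-361 cells (Homo sapiens) for antiproliferative activity, read by MTT assay, with a stated time of 72 h; a higher number here means a weaker inhibitor, a lower number a stronger inhibitor. Compound 2 has a value that cannot be told apart from that of compound 3, since a 1.3-fold higher number from compound 2 to compound 3 (0.11 log units; within the scatter) stays within the scatter, and it lies clear of compound 1, with a 2.1-fold lower number from compound 1 to compound 2 (0.33 log units; beyond the scatter). Compound 4 `CN(C)c1ccc(Nc2nc(-c3ccncc3)nc3c2CC(N)CC3)cc1` changes the group on the nitrogen of compound 2: 4-(dimethylamino)phenyl in place of 3-fluorophenyl on a nitrogen on an aromatic ring. Within the data shown here, only the step from the 4-fluorophenyl of compound 1 bears on this, and it was modest. Among the measured compounds shown here, no measured compound carries the entering group, so a modest rise in this assay is expected, though with wide uncertainty. The expected change is a 1.6-fold higher number from compound 2 to compound 4 (0.20 log units; within the scatter). For compound 4 the estimated value is 2200 nM, within an expected range of 700 nM to 7000 nM.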

Compound 4, half-maximal inhibitory concentration: 8100 nM
Compound 4: middle estimate off by 3.7-fold (0.57 log units), on the low side, and the stated range ends below it.
By their numbers in this assay, from the lowest: compounds 2, 3 and 1 (each within the scatter of the next, the first and the last beyond it); then compound 4.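

In this assay the group on this nitrogen can shift the number well beyond the scatter, with a 5.8-fold higher number from compound 2 to compound 4 (0.76 log units; beyond the scatter) for 4-(dimethylamino)phenyl in place of 3-fluorophenyl. The change also holds against the 4-fluorophenyl of compound 1, where dimethylamino in place of fluoro on an aromatic carbon gives a 2.7-fold higher number from compound 1 to compound 4 (0.43 log units; beyond the scatter) and so costs activity on its own. Nothing given here accounts for the rise. Going by these compounds, whether a smaller methylamino or a methoxy group would stay close to compound 2 remains open. So does whether dimethylamino would behave the same way elsewhere on the ring.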